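A Methyl Extension on Two Imidazolium Oxime Chains

The compounds below may be only part of what the source reports. "The series", "measured", "known", "first", "only" and "open" are said of these compounds alone.

Compound 1 `CC[n+]1ccn(CCN(C)C)c1/C=N/O` and compound 2 `CCC[n+]1ccn(CCN(C)C)c1/C=N/O` share one core and differ in a single place: methyl in place of hydrogen on a saturated chain carbon, two bonds along the chain from an aromatic nitrogen. In a physicochemical assay for lipophilicity (a lower number here means a more polar compound, a higher number a more lipophilic compound), compound 1 gives -2.71 and compound 2 gives -2.73, so the step of a number 0.02 log units lower from compound 1 to compound 2 (within the scatter) is one that cannot be told apart from repetition. Compound 3 `CN(CCCn1cc[n+](C)c1/C=N/O)S(=O)(=O)C(F)(F)F` carries a different core; the difference between the two cores is not broken down here. In this assay compound 3 gives -1.37, the highest of the three numbers, lying beyond the scatter from both compound 1 and compound 2. Compound 4 `CCN(CCCn1cc[n+](C)c1/C=N/O)S(=O)(=O)C(F)(F)F` is the same kind of change made on compound 3: methyl in place of hydrogen on a saturated chain carbon bound to a sulfonamide nitrogen. The place differs from the earlier one, where the carbon sat two bonds along the chain from an aromatic nitrogen rather than bound to a sulfonamide nitrogen. Resting on the small step seen from compound 1 to compound 2, a number 0.02 log units lower from compound 1 to compound 2 (within the scatter), the step of a number 0.22 log units higher from compound 3 to compound 4 (within the scatter) is expected to be small as well. In this assay compound 4 is estimated at -1.15, with a range from -1.6 to -0.7.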

Compound 4, distribution coefficient: -1.02
Beside the measured number, compound 4's estimate is 0.13 log units below it, within the range that was stated.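

In this assay, the methyl change gave a number 0.35 log units higher from compound 3 to compound 4 (beyond the scatter), whereas on the core of compound 1 it had given a number 0.02 log units lower from compound 1 to compound 2 (within the scatter), so the same kind of change did not stay within the scatter on both cores. This does not show that the core alone decides the size of the step: the methyl sits in a different place in each pair, on a saturated chain carbon bound to a sulfonamide nitrogen in one and two bonds along the chain from an aromatic nitrogen in the other, and each case rests on a single pair. Nothing available here offers an account of the difference between the two steps.

The compounds shown leave open whether the step would hold with the methyl two bonds along the chain from an aromatic nitrogen on the core of compound 3. They also leave open how a longer chain or a carboxylic acid, placed on a saturated chain carbon bound to a sulfonamide nitrogen, would read in this assay.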